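Imidazolylmethyl amines: cytotoxicity notes and one estimate

A few compounds are considered here, and "the series" means these few. Any claim that something is new, unique, unknown or untested is made for them only; others in the source may bear on it.

Measured compounds:
compound 1 `CCc1nc[nH]c1CN[C@@H]1C[C@@H]2C[C@H]([C@H]1C)C2(C)C` with 180000 nM in an ADME assay on MDCK cells (Canis lupus familiaris) for cytotoxicity, read by MTT assay, with a stated time of 48 h; a lower number here means that less compound is tolerated, a higher number that more compound is tolerated
compound 2 `C[C@@H]1[C@H]2C[C@@H](C[C@H]1NCc1[nH]cnc1C1CC1)C2(C)C` with 163000 nM in this assay
compound 3 `CCc1ncc(CN[C@@H]2C[C@@H]3C[C@H]([C@H]2C)C3(C)C)[nH]1` with 137000 nM in this assay

Compound 2 differs from compound 1 by cyclopropyl in place of ethyl on an aromatic carbon, and the step is a 1.1-fold lower number from compound 1 to compound 2 (0.04 log units; within the scatter). Compound 3 shares its atoms with compound 1 but joins them differently; the difference between the two cores is not broken down here. Within the data shown here, compound 4 `C[C@@H]1[C@H]2C[C@@H](C[C@H]1NCc1cnc(C3CC3)[nH]1)C2(C)C` differs from compound 3 by cyclopropyl in place of ethyl on an aromatic carbon, the same kind of change as the one from compound 1 to compound 2, though the place differs: between two ring nitrogen atoms and two ring bonds from the ring atom that bears a large group, rather than next to the ring nitrogen and next to that ring atom. Because a 1.1-fold lower number from compound 1 to compound 2 (0.04 log units; within the scatter) stayed within the scatter, compound 4 is expected to give a 1.1-fold lower number from compound 3 to compound 4 (0.04 log units; within the scatter) in this assay. The estimate for compound 4 is 125000 nM, from 70000 nM to 220000 nM.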

Compound 4, half-maximal cytotoxic concentration: 94500 nM
Compound 4: middle estimate off by 1.3-fold (0.12 log units), on the high side, within the range that was stated.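

In this assay, cyclopropyl in place of ethyl on an aromatic carbon gives a 1.4-fold lower number from compound 3 to compound 4 (0.16 log units; within the scatter), and this step does not stand apart from the earlier one on the other core: the same change on two cores in this assay, a 1.1-fold lower number (0.04 log units; within the scatter) from compound 1 to compound 2 and a 1.4-fold lower number (0.16 log units; within the scatter) from compound 3 to compound 4, 1.3-fold (0.12 log units) apart, within the scatter of two such steps. On these two cores, with the group in two different places on the ring, the change carries over without a difference that can be told from the scatter. Both steps lie within the scatter, however, so neither shows an effect of the change itself, and two pairs say nothing about cores beyond these.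

Still open, from the compounds shown here alone, is whether a different group on this aromatic carbon, such as an amine, a carboxylic acid or a longer chain, gives a step beyond the scatter.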